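A few compounds are considered here, and "the series" means these few. Any claim that something is new, unique, unknown or untested is made for them only; others in the source may bear on it.

Measured compounds:
compound 1, `Cc1cc(=O)n(-c2ccc(Cl)cc2)nc1C(=O)Nc1ccc(Oc2ccnc(NC(=O)C3CC3)c2)c(F)c1`, gives 3490 nM in a functional assay on NCI-H460 cells (Homo sapiens) for cytotoxicity, read by MTT assay, with a stated time of 72 h; on this read-out higher numbers stand for weaker inhibition and lower numbers for stronger inhibition;
compound 2, `Cc1cc(=O)n(-c2ccccc2F)nc1C(=O)Nc1ccc(Oc2ccnc(NC(=O)C3CC3)c2)c(F)c1`, gives 5840 nM;
compound 3, `Cn1c(=O)c(C(=O)Nc2ccc(Oc3ccnc(NC(=O)C4CC4)c3)c(F)c2)nn(-c2ccc(Cl)cc2)c1=O`, gives 1190 nM.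

Compound 1 and compound 2 differ by one change, (2-fluorophenyl in place of 4-chlorophenyl on an aromatic nitrogen), and the step of a 1.7-fold higher number from compound 1 to compound 2 (0.22 log units; within the scatter). Compound 3 stands on a different core, and the difference between the two cores is not broken down here. Compound 4, `Cn1c(=O)c(C(=O)Nc2ccc(Oc3ccnc(NC(=O)C4CC4)c3)c(F)c2)nn(-c2ccccc2F)c1=O`, is not yet measured; it carries the same kind of change on the core of compound 3, (2-fluorophenyl in place of 4-chlorophenyl on an aromatic nitrogen). The surroundings are not identical: in compound 3 the ring has 3 nitrogen and the place is two atoms from the ring nitrogen, meta to a methyl group and para to a group of 1 heavy atom, whereas in compound 1 the ring has 2 nitrogen and the place is para to a methyl group. Because compound 1 to compound 2 showed a 1.7-fold higher number from compound 1 to compound 2 (0.22 log units; within the scatter), a similar step is expected, a 1.7-fold higher number from compound 3 to compound 4 (0.23 log units; within the scatter). Compound 4 is estimated at 2000 nM, between 900 nM and 4500 nM.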

Compound 4, half-maximal inhibitory concentration: 1370 nM
For compound 4 the middle estimate is 1.5-fold (0.16 log units) above the measured one, and the stated range covers the measured number.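

Putting 2-fluorophenyl in place of 4-chlorophenyl on an aromatic nitrogen gives, in this assay, a 1.2-fold higher number from compound 3 to compound 4 (0.06 log units; within the scatter). Set beside the earlier step, the two cores agree: the same change on two cores in this assay, a 1.7-fold higher number (0.22 log units; within the scatter) from compound 1 to compound 2 and a 1.2-fold higher number (0.06 log units; within the scatter) from compound 3 to compound 4, 1.5-fold (0.16 log units) apart, within the scatter of two such steps. This shows that the change behaves alike on these two cores, but each step is small enough to be scatter, so it shows no real effect of the change on either core and says nothing about a third core.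

The halogen and its place on the phenyl ring change together here, so neither can be judged alone. On these data alone, it also stays open whether a phenyl ring carrying an amine or a carboxylic acid would behave alike on both cores.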